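Swapping Thiophene for Furan on the Shared Core

A few compounds are considered here, and "the series" means these few. Any claim that something is new, unique, unknown or untested is made for them only; others in the source may bear on it.

Compound 1 `Oc1ccc(-c2cc(-c3cccc(Cl)c3)nc(-c3ccccn3)c2)cc1`: in a functional assay on T47D cells (Homo sapiens) for cytotoxicity, read by CCK-8 assay and cell counting, with a stated time of 2 days (on this read-out lower numbers stand for stronger inhibition and higher numbers for weaker inhibition), compound 1 gives 27900 nM.
Compound 2 `Oc1ccc(-c2cc(-c3ccsc3)nc(-c3cccc(Cl)c3)c2)cc1`: in this assay compound 2 gives 7390 nM.

Among the measured compounds shown here, of the two numbers measured so far, compound 2 has the lowest, meaning the stronger inhibition of the pair; its only neighbour is compound 1, and the single measured step is a 3.8-fold lower number from compound 1 to compound 2 (0.58 log units; beyond the scatter). Compound 3 `Oc1ccc(-c2cc(-c3cccc(Cl)c3)nc(-c3ccco3)c2)cc1` has not yet been measured. It differs from compound 2 by furan-2-yl in place of thiophen-3-yl on an aromatic carbon. For the measured compounds named here, the one earlier step bears on this only loosely: there, a six-membered ring with one nitrogen gave way to a five-membered ring with one sulfur, whereas here one five-membered ring with a single hetero atom is exchanged for another of the same size, so the change is smaller in kind. A step in this assay that stays within the usual scatter, or is at most modest, in either direction, is therefore expected. For compound 3 the estimate is 9000 nM, with a range from 3000 nM to 27000 nM. The expected step is a 1.2-fold higher number from compound 2 to compound 3 (0.09 log units; within the scatter).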

Compound 3, half-maximal inhibitory concentration: 5220 nM
Compound 3: middle estimate off by 1.7-fold (0.24 log units), on the high side; measured number inside the range.
By their numbers in this assay, from the lowest: compounds 3 and 2 (each within the scatter of the next); then compound 1.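

At this aromatic carbon next to the ring nitrogen, this assay shows a 1.4-fold lower number from compound 2 to compound 3 (0.15 log units; within the scatter) and so does not separate the two five-membered rings, even though the hetero atom changes from sulfur to oxygen and the point of attachment on the ring changes with it. Furan-2-yl in place of pyridin-2-yl gives a clearer change, with a 5.3-fold lower number from compound 1 to compound 3 (0.73 log units; beyond the scatter) on the shared core. Among these three compounds, both five-membered rings therefore give lower numbers than pyridin-2-yl, none of the compounds goes against this, and the pattern now rests on two different rings rather than on thiophen-3-yl alone.

Nothing measured here explains why the numbers fall this way. Going by these compounds, it remains open whether thiophen-2-yl or furan-3-yl would separate the effect of the hetero atom from that of the point of attachment, and whether a plain phenyl ring, an amine or a carboxylic acid at this carbon would give numbers closer to those of the five-membered rings or to that of pyridin-2-yl.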